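Adding a Methyl to the Pyridyl Ring of Compound 3

The source may hold more compounds than are shown below. What is called first, only, known or untested is meant among the compounds shown, and "the series" means these compounds.

Of the compounds shown here, three sharing one core have been measured in an assay on Ltk cells with metabotropic glutamate receptor 5 (Homo sapiens) as the target, read by fluorescence and calcium flux; a lower number here means a stronger inhibitor, a higher number a weaker inhibitor. Compound 1, `CCOc1cc(C#N)cnc1Nc1cccc(C)n1`, gives 46 nM. Compound 2, `CCOc1cc(-c2cccc(F)c2)cnc1Nc1cccc(C)n1`, gives 126 nM. Compound 3, `CCOc1cc(-c2cccnc2)cnc1Nc1cccc(C)n1`, gives 12 nM, the lowest of the three numbers, and its steps to both other compounds lie beyond the scatter. The step of a 3.8-fold lower number from compound 1 to compound 3 (0.58 log units; beyond the scatter) and the step of an 11-fold lower number from compound 2 to compound 3 (1.02 log units; beyond the scatter) both lead to compound 3, whereas the step of a 2.7-fold higher number from compound 1 to compound 2 (0.44 log units; beyond the scatter) runs the other way.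

Compound 4, `CCOc1cc(-c2cnccc2C)cnc1Nc1cccc(C)n1`, is not yet measured. It differs from compound 3 by methyl in place of hydrogen on an aromatic carbon. For the measured compounds named here, none of the measured steps involves a methyl added to the pyridin-3-yl group, so no step bears directly on this change; the measured steps only replace the whole group on that aromatic carbon. Going by the values given here, with no comparable step to lean on, the expectation for compound 4 in this assay is a number close to that of compound 3, and the step of a 1.7-fold higher number from compound 3 to compound 4 (0.22 log units; within the scatter) is therefore estimated to stay near or within the scatter. Compound 4 is expected to give about 20 nM, with a range from 6 nM to 70 nM.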

Compound 4, half-maximal inhibitory concentration: 45 nM
Compound 4: the middle estimate sits 2.3-fold (0.35 log units) below what was measured, and the stated range covers the measured number.
By their numbers in this assay, from the lowest: compound 3; then compounds 4 and 1 (each within the scatter of the next); then compound 2.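

A single methyl on the pyridin-3-yl group, ortho to a large group and opposite the ring nitrogen, is not a silent addition at this position: the record shows a 3.8-fold higher number from compound 3 to compound 4 (0.57 log units; beyond the scatter). The earlier compounds shown here only exchanged whole groups on this aromatic carbon, whereas this result shows that a small change within the best of those groups can alter the reading, although the 4-methylpyridin-3-yl group still keeps a lead over the 3-fluorophenyl group, with a 2.8-fold lower number from compound 2 to compound 4 (0.45 log units; beyond the scatter). Set against the nitrile, it gives a 1.0-fold lower number from compound 1 to compound 4 (0.01 log units; within the scatter), so in this assay the methyl removes the whole advantage that the unsubstituted pyridin-3-yl group held over the nitrile, and nothing available explains why this happens.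

Going by these compounds, it remains open whether this loss belongs to a methyl at this place alone, or whether a methyl elsewhere on the pyridin-3-yl group, or a chlorine, methoxy or amino group at the same place, would read differently. On these data alone, it also remains open whether the same methyl would shift the number by a similar amount on the 3-fluorophenyl group.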